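The compounds below may be only part of what the source reports. "The series", "measured", "known", "first", "only" and "open" are said of these compounds alone.

The series rests on one core. Compound 1 `COc1cc(/C=C/C(=O)OCCc2cccc(F)c2)cc(OC)c1O` and compound 2 `COc1cc(/C=C/C(=O)OCCc2ccccc2F)cc(OC)c1O` differ by the step of a 1.0-fold higher number from compound 1 to compound 2 (0.02 log units; within the scatter), and compound 3 `COc1cc(/C=C/C(=O)OCCc2cccc(C(F)(F)F)c2)cc(OC)c1O` differs from compound 1 by the step of a 1.2-fold lower number from compound 1 to compound 3 (0.06 log units; within the scatter). In an assay on PMNL cells for inhibition of Polyunsaturated fatty acid 5-lipoxygenase (Homo sapiens), read by HPLC, with stated times of 5 min and 15 min (on this read-out higher numbers stand for weaker inhibition and lower numbers for stronger inhibition), compound 1 gives 230 nM, compound 2 gives 240 nM and compound 3 gives 200 nM. On these numbers compound 2 is separated from compound 1 and from compound 3 only by amounts within the scatter. Compound 4 `COc1cc(/C=C/C(=O)OCCc2ccccc2C(F)(F)F)cc(OC)c1O` carries the change (trifluoromethyl in place of fluoro on an aromatic carbon). The measured step that bears on it is the same exchange made in compound 3, a 1.2-fold lower number from compound 1 to compound 3 (0.06 log units; within the scatter), which stayed within the scatter. In this assay the expected step is therefore a 1.0-fold lower number from compound 2 to compound 4 (0.02 log units; within the scatter), none beyond the scatter. Compound 4 is estimated at 230 nM, within 120 nM to 450 nM.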

Compound 4, half-maximal inhibitory concentration: 350 nM
Estimate against measurement, compound 4: 1.5-fold (0.18 log units) below; low and high end bracket the measured number.
By their numbers in this assay, from the lowest: compounds 3, 1, 2 and 4 (each within the scatter of the next).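

At the aromatic carbon ortho to a large group, trifluoromethyl in place of fluoro gives a 1.5-fold higher number from compound 2 to compound 4 (0.16 log units; within the scatter) in this assay, so the larger group is accommodated here without a step beyond the scatter. The exchange therefore stays within the scatter on both cores, and the two steps cannot be told apart: the same change on two cores in this assay, a 1.2-fold lower number (0.06 log units; within the scatter) from compound 1 to compound 3 and a 1.5-fold higher number (0.16 log units; within the scatter) from compound 2 to compound 4, 1.7-fold (0.22 log units) apart, within the scatter of two such steps

Still open, going by these compounds, is whether an amine or a carboxylic acid on this aromatic carbon would give a step beyond the scatter. On these data alone, the effect of a longer chain in place of the present saturated chain also remains open.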